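A Chloro-for-Bromo Swap on a Monoamine Oxidase Inhibitor Series

A few compounds are considered here, and "the series" means these few. Any claim that something is new, unique, unknown or untested is made for them only; others in the source may bear on it.

Of the compounds shown here, three sharing one core have been measured in an in vitro assay on cells for inhibition of Amine oxidase [flavin-containing] A (Homo sapiens), read by coupled enzyme assay, with a stated time of 20 min; a lower number here means a stronger inhibitor, a higher number a weaker inhibitor. Compound 1 `Cn1c(=O)c2c(nc(COc3cccc(Br)c3)n2C)n(C)c1=O` gives 34000 nM in this assay and stands second highest of the three numbers: its nearest neighbour is compound 3 `Cc1cccc(OCc2nc3c(c(=O)n(C)c(=O)n3C)n2C)c1` with 18800 nM, and its furthest is compound 2 `Cn1c(=O)c2c(nc(CCSc3ccc(Cl)cc3)n2C)n(C)c1=O` with 142000 nM, which differs in more than one place and lies beyond the scatter. Within the data shown here, the only single-point step recorded, a 1.8-fold lower number from compound 1 to compound 3 (0.26 log units; within the scatter), came from methyl in place of bromo on an aromatic carbon and stayed within the scatter.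

Compound 4 `Cn1c(=O)c2c(nc(COc3cccc(Cl)c3)n2C)n(C)c1=O` differs from compound 1 by chloro in place of bromo on an aromatic carbon. The step from compound 1 to compound 3 bears on it, since it changes the same aromatic carbon, and it showed no movement beyond the scatter. Among the measured compounds shown here, the same is therefore expected here: no step of either direction beyond the scatter in this assay. Compound 4 is estimated to give 40000 nM, with a range from 15000 nM to 100000 nM, which is the expected step of a 1.2-fold higher number from compound 1 to compound 4 (0.07 log units; within the scatter).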

Compound 4, half-maximal inhibitory concentration: "not active" (no number reported)
Compound 4 has no reported number here, so the estimate cannot be set against anything.
By their numbers in this assay, from the lowest: compounds 3 and 1 (each within the scatter of the next); then compound 2.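

Among these compounds, compound 4 is recorded as "not active" with no number in this assay, so no step from compound 1 to compound 4 can be read. Nothing shown offers an explanation for this result. The compounds shown leave open how far 3-bromophenyl to 3-chlorophenyl shifts the number.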